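From compound 2 to compound 4: a benzyl exchange

The source may hold more compounds than are shown below. What is called first, only, known or untested is meant among the compounds shown, and "the series" means these compounds.

compound 1 `C=CCOc1cc(OC)c(C(=O)/C=C/Cc2ccccc2)c(OCC=C)c1` gives 14800 nM
compound 2 `COc1cc(O)cc(O)c1C(=O)/C=C/c1ccc(C)cc1` gives 16500 nM
compound 3 `C=CCOc1cc(OC)c(C(=O)/C=C/c2ccccc2F)c(OCC=C)c1` gives 13300 nM

In a toxicity assay on cells (Macrophage, Mus musculus, strain BALB/c) for cytotoxicity, read by MTT assay (a lower number here means a stronger inhibitor, a higher number a weaker inhibitor), compound 2 lies within the scatter of both compound 1 and compound 3. Compound 4 `COc1cc(O)cc(O)c1C(=O)/C=C/Cc1ccccc1` carries benzyl in place of 4-methylphenyl on a double-bonded chain carbon bound to a double-bonded chain carbon, and the counted difference from compound 2 is benzyl in place of 4-methylphenyl on a double-bonded chain carbon bound to a double-bonded chain carbon and nothing more. For the measured compounds named here, the one measured step that bears on this is a 1.1-fold lower number from compound 1 to compound 3 (0.05 log units; within the scatter) on a different core, where 2-fluorophenyl replaces benzyl at that place. No step beyond the scatter is therefore expected in this assay here. The expected step is a 1.0-fold lower number from compound 2 to compound 4 (0.01 log units; within the scatter) in size. Compound 4 is estimated at 16000 nM with an expected range from 8000 nM to 32000 nM in this assay.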

Compound 4, half-maximal inhibitory concentration: 27000 nM
Beside the measured number, compound 4's estimate is 1.7-fold (0.23 log units) below it; the range from low to high includes it.
By their numbers in this assay, from the lowest: compounds 3, 1, 2 and 4 (each within the scatter of the next, the first and the last beyond it).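

In this assay the exchange of 4-methylphenyl for benzyl gives a 1.6-fold higher number from compound 2 to compound 4 (0.21 log units; within the scatter) and so provides a second step at this place, now on a different core from the earlier one. Together with a 1.1-fold lower number from compound 1 to compound 3 (0.05 log units; within the scatter) it shows that both exchanges measured on a double-bonded chain carbon bound to a double-bonded chain carbon stay within the scatter, on two cores. On these data alone, whether an amine, a carboxylic acid or a longer chain at this place would give a step beyond the scatter stays open. No measurement here bears on what lies behind these steps.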